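Series notes: one phenyl removed from the ether chain carbon

The source may report more compounds than this note shows. Statements on the series, on what has been measured and on what is new or still open speak of the compounds shown alone.

The series is followed in an assay for displacement of a labelled ligand from 3-oxo-5-alpha-steroid 4-dehydrogenase 1 (Rattus norvegicus), at pH 6.6, tested at 10 uM; a higher number here means more inhibition at the concentration tested (going by the name of the read-out), a lower number less inhibition. Compound 1 `O=C(O)c1ccc(C(=O)c2ccc(Oc3ccccc3)cc2)cc1` gives 53% in this assay. Going by the values given here, compound 2 `O=C(O)c1ccc(C(=O)c2ccc(OC(c3ccccc3)c3ccccc3)cc2)cc1` gives 73% in this assay, the higher of the two numbers so far; its nearest neighbour is compound 1, whose number lies lower by a margin beyond the scatter. Among the compounds with values here, no pair of measured compounds differs in a single place, so no measured step is available as a direct guide.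

Compound 3 `O=C(O)c1ccc(C(=O)c2ccc(OCc3ccccc3)cc2)cc1` is not yet measured. Relative to compound 2 it shows (hydrogen in place of phenyl on a saturated chain carbon bound to an aromatic carbon and an oxygen on an aromatic ring). Compound 3 thus carries a substituent intermediate in size between those of compound 1 and compound 2, and the two measured values of compound 1 and compound 2 are the only anchors. A number between them is the plainest expectation. Compound 3 is estimated to give about 62% in this assay, with a plausible range from 45% to 78%. The step from compound 2 to compound 3 is expected to be a number 11 percentage points lower from compound 2 to compound 3 (beyond the scatter), a modest fall at about the edge of the scatter, possibly none at all.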

Compound 3, a percentage reported as inhibition, at one concentration (the size of the read-out at that concentration, not a potency): 64%
For compound 3 the middle estimate is 2 percentage points below the measured one; the measured number falls inside the stated range.
By their numbers in this assay, from the lowest: compound 1; then compounds 3 and 2 (each within the scatter of the next).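

In this assay, hydrogen in place of phenyl on a saturated chain carbon bound to an aromatic carbon and an oxygen on an aromatic ring gives a number 9 percentage points lower from compound 2 to compound 3 (within the scatter), so the second phenyl at this position is not shown to be needed for the inhibition read at the concentration tested. Benzyl in place of phenyl on an oxygen on an aromatic ring gives a number 11 percentage points higher from compound 1 to compound 3 (beyond the scatter), a modest step and the only one of these two to clear the scatter, which makes the presence of the saturated chain carbon carrying a phenyl the change that registers in this small set. Nothing measured here speaks to the reason for either step.

Still open, from the compounds shown here alone, is whether phenethyl in place of benzyl on the oxygen, or an amine or hydroxyl in place of hydrogen on the saturated chain carbon, would keep the read-out at this level. A single-concentration percentage also leaves open whether compound 2 and compound 3 would separate in a full potency measurement.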